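Adding a nitrile to the pyrazole of compound 3

A few compounds are considered here, and "the series" means these few. Any claim that something is new, unique, unknown or untested is made for them only; others in the source may bear on it.

Compound 1, `N#Cc1cnn(C(=O)NCc2ccc(OCc3ccccc3)cc2)c1`: 100 nM
Compound 2, `Cc1cnn(C(=O)N(C)CCN(C)Cc2ccc(OCc3ccccc3)cc2)c1`: 1200 nM
Compound 3, `CN(CCN(C)C(=O)n1cccn1)Cc1ccc(OCc2ccccc2)cc1`: 660 nM

The three compounds were tested in an assay on membranes from brain for binding affinity to Monoglyceride lipase (Mus musculus), read by fluorescence, with stated times of 1 h and 30 min; a lower number here means a stronger inhibitor, a higher number a weaker inhibitor. Compound 3 stands second highest of the three numbers: its nearest neighbour is compound 2, and the step from there is a 1.8-fold lower number from compound 2 to compound 3 (0.26 log units; within the scatter), so the two are not distinguishable. Compound 1 lies furthest away, with a clearly lower number, but it differs from compound 3 in more than one place, so no single step can be read from that pair.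

Compound 4, `CN(CCN(C)C(=O)n1cc(C#N)cn1)Cc1ccc(OCc2ccccc2)cc1`, is the next to be measured. It differs from compound 3 by cyano in place of hydrogen on an aromatic carbon; the same change read one bond further out turns 1H-pyrazol-1-yl into 4-cyano-1H-pyrazol-1-yl. Within the data shown here, of the measured steps, only the one from compound 2 to compound 3 touches that ring position, and it was within the scatter. Compound 1 also carries the cyano group and shows the lowest number, which hints at a gain, though its other parts differ. On that basis the expected step of a 3.0-fold lower number from compound 3 to compound 4 (0.48 log units; beyond the scatter) is a moderate move toward a lower number in this assay. Compound 4 is therefore expected to give about 220 nM, estimated between 60 nM and 800 nM.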

Compound 4, half-maximal inhibitory concentration: 260 nM
Compound 4: the middle estimate sits 1.2-fold (0.07 log units) below what was measured; the range from low to high includes it.
By their numbers in this assay, from the lowest: compound 1; then compound 4; then compounds 3 and 2 (each within the scatter of the next).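

Among these compounds, at the aromatic carbon two ring bonds from the ring nitrogen, the nitrile gives the first change in this assay that lies beyond the scatter: cyano in place of hydrogen gives a 2.5-fold lower number from compound 3 to compound 4 (0.40 log units; beyond the scatter), whereas hydrogen in place of methyl at that carbon gave only a 1.8-fold lower number from compound 2 to compound 3 (0.26 log units; within the scatter), which lies within it. Cyano in place of methyl gives a 4.6-fold lower number from compound 2 to compound 4 (0.66 log units; beyond the scatter), so with the rest of the molecule held constant, cyano stands apart from both hydrogen and methyl, and those two cannot be told apart. No measurement shown here bears on the reason for these steps.

Among the compounds shown here, how other groups at this carbon would read remains open, for example a carboxylic acid, an amine or a methoxy group, and so does whether any of them would give a number lower than the one for compound 4 at 260 nM. For the compounds shown here, compound 1 differs from the other compounds in more than one place, so no step to it can be read, and what the nitrile contributes on its shorter chain stays unknown.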